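Cyclopentane acid series: shortening the acid side chain

The source may hold more compounds than are shown below. What is called first, only, known or untested is meant among the compounds shown, and "the series" means these compounds.

Measured compounds:
compound 1 `O=C(O)CC1CCC(c2ccc(OCc3ccc4ccccc4n3)cc2)C1` gives 22 nM
compound 2 `CC(CCCc1nnn[nH]1)c1cccc(OCc2ccc3ccccc3n2)c1` gives 31 nM
compound 3 `CC(CCCc1nnn[nH]1)c1ccc(OCc2ccc3ccccc3n2)cc1` gives 43 nM

All three numbers come from an assay on membranes from lung (Cavia porcellus) for binding affinity to cysteinyl leukotriene receptor (Homo sapiens); on this read-out lower numbers stand for stronger inhibition and higher numbers for weaker inhibition. Compound 1 shows the lowest of the three numbers, but its gaps to compound 2 and to compound 3 both lie within the usual scatter, so nothing separates the three with confidence on this read-out; the tetrazole-bearing compounds 2 and 3 sit in the same band as the cyclopentane acid.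

Compound 4 `O=C(O)C1CCC(c2ccc(OCc3ccc4ccccc4n3)cc2)C1` is not yet measured. It differs from compound 1 in one place: carboxy in place of carboxymethyl on a saturated ring carbon. Going by the values given here, no measured pair in this set shows the same change, so there is no step to lean on. A change at the acid end of the side chain, while the shared core is kept, is expected to cost somewhat in this assay, but not far beyond the scatter. The step from compound 1 to compound 4 is estimated as a 1.8-fold higher number from compound 1 to compound 4 (0.26 log units; within the scatter). For compound 4 the expected value is 40 nM, with a range from 12 nM to 130 nM.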

Compound 4, inhibition constant: 43 nM
The estimate for compound 4 lay 1.1-fold (0.03 log units) below the measured number; measured number inside the range.
By their numbers in this assay, from the lowest: compounds 1, 2, 3 and 4 (each within the scatter of the next).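

Carboxy in place of carboxymethyl on a saturated ring carbon is the first change in this set that can be read in one place, and in this assay it appears as a 2.0-fold higher number from compound 1 to compound 4 (0.29 log units; within the scatter) on the shared core. At this position, two ring bonds from the ring atom that bears the large group, the shorter carboxy group therefore stays in the same band as carboxymethyl, and this read-out does not separate the two. No measurement at hand speaks to why the step has this size.

Going by these compounds, whether a longer chain such as carboxyethyl, or an amide or an amine in place of the carboxylic acid at this ring carbon, would move the number beyond the scatter remains open. Also open, on these data alone, is how the tetrazole seen in compounds 2 and 3 would read at this ring carbon on the same core.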